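Sulfonamide chain change from compound 3 to compound 4

The source may hold more compounds than are shown below. What is called first, only, known or untested is meant among the compounds shown, and "the series" means these compounds.

compound 1 `CCCCNS(=O)(=O)c1ccc(Nc2ncc3c(n2)N(C2CCCC2)[C@H](CC)C(=O)N3C)cc1`: 412 nM
compound 2 `CCCNS(=O)(=O)c1ccc(Nc2ncc3c(n2)N(C2CCCC2)[C@H](CC)C(=O)N3C)cc1`: 548 nM
compound 3 `CC[C@@H]1C(=O)N(C)c2cnc(Nc3ccc(S(=O)(=O)NCCCO)cc3)nc2N1C1CCCC1`: 331 nM

All three values come from a functional assay on K562 cells (Homo sapiens) for antiproliferative activity, read by CCK-8 assay, with a stated time of 72 h; a higher number here means a weaker inhibitor of growth, a lower number a stronger inhibitor of growth. Compound 3 is not separated from the other two: a 1.2-fold lower number from compound 1 to compound 3 (0.10 log units; within the scatter) and a 1.7-fold lower number from compound 2 to compound 3 (0.22 log units; within the scatter). Compound 4 `CC[C@@H]1C(=O)N(C)c2cnc(Nc3ccc(S(=O)(=O)NCC(C)C)cc3)nc2N1C1CCCC1` brings (isopropyl in place of 2-hydroxyethyl on a saturated chain carbon bound to a sulfonamide nitrogen), which also reads 3-hydroxypropyl to isobutyl. No branched chain has been measured. The nearest evidence is therefore the small steps on this same chain, those two and a 1.3-fold higher number from compound 1 to compound 2 (0.12 log units; within the scatter). No step beyond the scatter is expected in this assay, and the estimate leans toward the chains without hydroxy, in compound 2 at 548 nM and compound 1 at 412 nM. The expected step is a 1.3-fold higher number from compound 3 to compound 4 (0.10 log units; within the scatter). The estimated value for compound 4 is 420 nM, with an expected range of 230 nM to 750 nM.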

Compound 4, concentration for 50% growth inhibition: 705 nM
Beside the measured number, compound 4's estimate is 1.7-fold (0.22 log units) below it; the range from low to high includes it.
By their numbers in this assay, from the lowest: compounds 3, 1, 2 and 4 (each within the scatter of the next, the first and the last beyond it).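

In this assay, for the compounds shown here, 3-hydroxypropyl to isobutyl gives the first step on this chain beyond the scatter, though a modest one: a 2.1-fold higher number from compound 3 to compound 4 (0.33 log units; beyond the scatter). Among the chains without hydroxy, the branch does not separate isobutyl from the straight chains, with a 1.3-fold higher number from compound 2 to compound 4 (0.11 log units; within the scatter) and a 1.7-fold higher number from compound 1 to compound 4 (0.23 log units; within the scatter). No measurement shown accounts for the step from 3-hydroxypropyl to isobutyl.

Still open, going by these compounds, is where an amine or a carboxylic acid at the end of this chain would fall. On these data alone, a longer chain ending in hydroxy is equally open, as is a branched chain carrying hydroxy.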